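The compounds below may be only part of what the source reports. "The series", "measured", "known", "first", "only" and "open" are said of these compounds alone.

Compound 1 `Cc1ccc(S(=O)(=O)N2CCC(N3CCC(C)CC3)CC2)cc1C`: > 5000 nM (a limit)
Compound 2 `CC1CCN(C2CCN(S(=O)(=O)c3cccc(-c4ccc5ccccc5c4)c3)CC2)CC1`: > 5000 nM (a limit)
Compound 3 `CC1CCN(C2CCN(S(=O)(=O)c3ccc(Cl)nc3)CC2)CC1`: > 10000 nM (a limit)

All three compounds were tested in an ADME assay on HCT-116 cells (Homo sapiens) for cytotoxicity, read by CellTiter-Glo, with a stated time of 72 h (a higher number here means a weaker inhibitor, a lower number a stronger inhibitor), and none gave a number. Compound 3 stands at the limit of > 10000 nM in this assay, at which 1 of the 3 values shown sits. Compound 1 and compound 2 stand at the limit of > 5000 nM in this assay, at which 2 of the 3 values shown sit.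

Compound 4 `CC1CCN(C2CCN(S(=O)(=O)c3cccc(Cl)c3)CC2)CC1` has yet to be measured in this assay. It carries 3-chlorophenyl in place of 6-chloropyridin-3-yl on a sulfonyl sulfur.

Within the data shown here, the one measured step that bears on this change also exchanges the group on the sulfonyl sulfur. It is a step that the two limits leave unreadable from compound 1 to compound 3, so it offers no size to carry over. No step beyond the scatter is therefore expected, and no direction can be argued. The expected step is a number no higher from compound 3 to compound 4 (the limit leaves the size open). Compound 4 is estimated at 10000 nM, with an expected range from 4000 nM to 30000 nM, and it will probably be reported only as a limit.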

Compound 4, half-maximal inhibitory concentration: > 5000 nM
Compound 4 was reported as a limit; the forecaster's own chance of this, stated with the estimate: 85%; the middle value is on the limit's open side.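

In this assay compound 4 gives > 5000 nM, which is a limit. With all four values being limits, the steps to compound 4 from compound 1, compound 2 and compound 3 cannot be read. The compounds shown leave open whether exchanging the group on the sulfonyl sulfur changes the result in this assay at all.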